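The compounds below may be only part of what the source reports. "The series", "measured", "known", "first", "only" and "open" are said of these compounds alone.

Compound 1 `Cc1cc(/C=C2\SC(=S)N(Cc3ccc(Br)cc3)C2=O)c(C)n1-c1ccc(O)c(C(=O)O)c1`: 94400 nM
Compound 2 `Cc1cc(/C=C2\SC(=S)N(Cc3cccc(Br)c3)C2=O)c(C)n1-c1ccc(O)c(C(=O)O)c1`: 48200 nM

In an ADME assay on MT2 cells (Homo sapiens) for cytotoxicity, read by XTT assay, with a stated time of 4 days (on this read-out higher numbers stand for lower toxicity in this test and lower numbers for higher toxicity in this test), compound 2 gives 48200 nM, while compound 1 gives 94400 nM; the step of a 2.0-fold lower number from compound 1 to compound 2 (0.29 log units; within the scatter) lies within the scatter, so the two numbers are not distinguishable. Compound 3 `COc1cccc(CN2C(=O)/C(=C/c3cc(C)n(-c4ccc(O)c(C(=O)O)c4)c3C)SC2=S)c1` differs from compound 2 by methoxy in place of bromo on an aromatic carbon. Among the measured compounds shown here, the only measured step, a 2.0-fold lower number from compound 1 to compound 2 (0.29 log units; within the scatter), concerns a different change and gives no direct guide to this one. With nothing in the data pointing to a shift, the expected step is a 1.1-fold higher number from compound 2 to compound 3 (0.06 log units; within the scatter), none beyond the scatter. Compound 3 is therefore estimated at 55000 nM, within a range from 20000 nM to 150000 nM.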

Compound 3, half-maximal cytotoxic concentration: 102000 nM
Compound 3: middle estimate off by 1.9-fold (0.27 log units), on the low side, and the stated range covers the measured number.
By their numbers in this assay, from the lowest: compounds 2, 1 and 3 (each within the scatter of the next, the first and the last beyond it).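

Among the compounds shown here, replacing bromo with methoxy on this aromatic carbon gives the first step beyond the scatter in this assay: a 2.1-fold higher number from compound 2 to compound 3 (0.33 log units; beyond the scatter), a modest move towards lower toxicity in this test. Yet a 1.1-fold higher number from compound 1 to compound 3 (0.03 log units; within the scatter), so the 3-methoxyphenyl and 4-bromophenyl compounds cannot be told apart. Nothing available here explains the shift. The compounds shown leave open how other groups on this carbon, such as an amine or a nitrile, would read. A single modest step also cannot show whether the change would hold on other compounds.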